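Difluoromethyl for Carboxymethyl: Tolerance on Kidney Cells

A few compounds are considered here, and "the series" means these few. Any claim that something is new, unique, unknown or untested is made for them only; others in the source may bear on it.

Compound 1 `Cc1ccc2cc(CN(Cc3ccc(F)cc3)Cc3ccc(C(C)C)cc3)c(=O)[nH]c2c1` gives > 33000 nM in a toxicity assay on MDCK cells (Canis lupus familiaris) for cytotoxicity, read by crystal violet staining, with a stated time of 48 h; a higher number here means that more compound is tolerated, a lower number that less compound is tolerated.
Compound 2 `Cc1ccc2[nH]c(=O)c(CN(Cc3cccc(F)c3)Cc3ccc4ccccc4c3)cc2c1` gives > 5000 nM in this assay.
Compound 3 `Cc1ccc2[nH]c(=O)c(CN(Cc3ccc(OCC(=O)O)cc3)Cc3ccc(C(C)(C)C)cc3)cc2c1` gives > 10000 nM in this assay.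

Each of these three values is a limit of the assay, not a number. Among the measured compounds shown here, compound 3 stands at the limit of > 10000 nM in this assay, at which 1 of the 3 values shown sits, and the other two compounds also stop at limits, so no compound among the three shows a measurable half-maximal cytotoxic concentration.

Compound 4 `Cc1ccc2[nH]c(=O)c(CN(Cc3ccc(OC(F)F)cc3)Cc3ccc(C(C)(C)C)cc3)cc2c1` differs from compound 3 by difluoromethyl in place of carboxymethyl on an oxygen on an aromatic ring. For the measured compounds named here, no measured pair in this assay shares this change, so nothing here shows how it moves tolerance. Compound 4 is expected to stay near compound 3, with a step that the limit leaves unreadable from compound 3 to compound 4 that lies within the scatter, most likely again at a limit. Compound 4 is estimated at 15000 nM, between 5000 nM and 50000 nM.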

Compound 4, half-maximal cytotoxic concentration: > 5000 nM
Compound 4 ended at the assay's limit (the forecaster's own chance of this, stated with the estimate: 75%); the middle value lies beyond the limit too.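

Among the compounds shown here, compound 3 and compound 4 both stop at limits in this assay, and no step between them can be read. The compounds shown leave open how difluoromethyl in place of carboxymethyl moves tolerance, and where any of these compounds reaches its half-maximal cytotoxic concentration.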